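A few compounds are considered here, and "the series" means these few. Any claim that something is new, unique, unknown or untested is made for them only; others in the source may bear on it.

Two close relatives share one core, a saturated six-membered ring bearing a carbonyl and attached through nitrogen to a methyl-substituted phenyl ring; they differ only in where the methyl sits on that phenyl ring. Compound 1 `Cc1ccccc1N1CCCC(=O)N1` and compound 2 `Cc1ccc(N2CCCC(=O)N2)cc1` were both tested in an assay on isolated protein for inhibition of Polyunsaturated fatty acid 5-lipoxygenase (Homo sapiens); a lower number here means a stronger inhibitor, a higher number a weaker inhibitor. In this assay compound 1 gives 57000 nM, while compound 2 gives 277000 nM. Of the two numbers, compound 1 has the lower one; compound 2 lies beyond the usual scatter above it, so compound 1 is the stronger inhibitor of this pair.

Compound 3 `CCc1ccccc1N1CCCC(=O)N1` has not yet been measured. It differs from compound 1 by methyl in place of hydrogen on a saturated chain carbon bound to an aromatic carbon. Among the compounds with values here, with no step between measured compounds of this kind to lean on, the expectation is modest: a change this small is expected to shift the number by little, and if anything toward a somewhat stronger inhibitor. The step from compound 1 to compound 3 is therefore expected to be a 1.4-fold lower number from compound 1 to compound 3 (0.15 log units; within the scatter). For compound 3 the estimated value in this assay is 40000 nM, with a range from 15000 nM to 150000 nM.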

Compound 3, half-maximal inhibitory concentration: 39000 nM
The estimate for compound 3 lay 1.0-fold (0.01 log units) above the measured number, within the range that was stated.
By their numbers in this assay, from the lowest: compounds 3 and 1 (each within the scatter of the next); then compound 2.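

Methyl in place of hydrogen on a saturated chain carbon bound to an aromatic carbon, the change that can also be read as methyl to ethyl, gives a 1.5-fold lower number from compound 1 to compound 3 (0.16 log units; within the scatter) in this assay, so the two numbers cannot be told apart. Within the data shown here, the earlier pair showed only that the two placements of the methyl on the phenyl ring give different numbers, whereas this step is the first look at the size of the group at one placement, and here the position takes one more carbon without a difference beyond the scatter. No measurement is available that explains why the numbers for this pair stand so close.

From the compounds shown here alone, what remains open is whether this position would still take something larger, such as a propyl group or a longer chain, or a group of a different kind, such as an amine or a carboxylic acid, and whether any of these would move the number beyond the scatter in either direction. Going by these compounds, it is also open whether swapping methyl for ethyl at the placement found in compound 2 would give a similarly small step.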